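Aryl Ketone Exchange and Vero Cell Cytotoxicity

A few compounds are considered here, and "the series" means these few. Any claim that something is new, unique, unknown or untested is made for them only; others in the source may bear on it.

Compound 1 `COC(=O)c1cc(-c2cccc(NC(=O)c3ccc(/C=C/C(=O)c4cccc([N+](=O)[O-])c4)cc3)c2)on1` gives > 40 ug/mL in an ADME assay on Vero cells (Chlorocebus sabaeus) for cytotoxicity, read by MTT assay, with a stated time of 72 h (on this read-out lower numbers stand for higher toxicity in this test and higher numbers for lower toxicity in this test), which is a limit of the assay and not a number.
Compound 2 `CCOc1ccc(C(=O)/C=C/c2ccc(C(=O)Nc3cccc(-c4cc(C(=O)OC)no4)c3)cc2)cc1` gives > 40 ug/mL in this assay, again a limit of the assay.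
Compound 3 `COC(=O)c1cc(-c2cccc(NC(=O)c3ccc(/C=C/C(=O)c4ccc(F)cc4F)cc3)c2)on1` gives > 40 ug/mL in this assay, also a limit of the assay.

Compound 3 therefore stands where every measured compound stands: at the limit of this assay, with no number behind it. All three values share this position (the limit of > 40 ug/mL in this assay, at which 3 of the 3 values shown sit). The measured steps cannot be read for that reason: the change from 3-nitrophenyl to 4-ethoxyphenyl on the carbonyl carbon a step that the two limits leave unreadable from compound 1 to compound 2, the change to 2,4-difluorophenyl a step that the two limits leave unreadable from compound 1 to compound 3, and the change between those two groups a step that the two limits leave unreadable from compound 2 to compound 3 all lie between two limits.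

Compound 4 `COC(=O)c1cc(-c2cccc(NC(=O)c3ccc(/C=C/C(=O)c4ccc(OC)c([N+](=O)[O-])c4)cc3)c2)on1` is the next member. Its structural change is 4-methoxy-3-nitrophenyl in place of 2,4-difluorophenyl on a carbonyl carbon. Because each comparable exchange of the group on the carbonyl carbon left the value at the limit (the limit of > 40 ug/mL in this assay, at which 3 of the 3 values shown sit), no step beyond the scatter is expected in this assay. Compound 4 is therefore expected to give about 45 ug/mL, with a plausible range from 25 ug/mL to 90 ug/mL. The expected step is a step that the limit leaves unreadable from compound 3 to compound 4, which in all likelihood means another value reported only as a limit.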

Compound 4, half-maximal cytotoxic concentration: > 40 ug/mL
Compound 4: a limit, no number (the forecaster's own chance of this, stated with the estimate: 85%); the middle value is on the limit's open side.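

No step from compound 1, compound 2 or compound 3 to compound 4 can be read, because both ends of each comparison are limits of this assay and not numbers: the limit of > 40 ug/mL in this assay, at which 4 of the 4 values shown sit.

The compounds shown leave open whether exchanging the group on the carbonyl carbon changes toxicity in this assay at all, and what number any of these four compounds would give.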